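A few compounds are considered here, and "the series" means these few. Any claim that something is new, unique, unknown or untested is made for them only; others in the source may bear on it.

Going by the values given here, compound 2 `COc1ccc(-c2[nH]c3ccc(OC)cc3c2/C=C(\C#N)S(=O)(=O)c2ccccc2)cc1` gives 4600 nM in a functional assay on OVCAR-5 cells (Homo sapiens) for inhibition, read by sulforhodamine B assay, with a stated time of 48 h (a lower number here means a stronger inhibitor of growth, a higher number a weaker inhibitor of growth), and stands at the higher of the two numbers so far. Compound 1 `COc1ccc(-c2[nH]c3ccccc3c2/C=C(\C#N)S(=O)(=O)c2ccccc2)cc1` gives 1900 nM in this assay, so the step of a 2.4-fold higher number from compound 1 to compound 2 (0.38 log units; beyond the scatter) is the only measured one on record. Compound 3 `COc1ccc2[nH]c(-c3ccccc3)c(/C=C(\C#N)S(=O)(=O)c3ccccc3)c2c1` differs from compound 2 by hydrogen in place of methoxy on an aromatic carbon, a change at another place than the measured step. That step offers only a loose guide, a methoxy added elsewhere having raised the number modestly. A modest lowering, a 1.4-fold lower number from compound 2 to compound 3 (0.16 log units; within the scatter), is expected, near the scatter. Compound 3 is estimated at 3200 nM in this assay, between 1400 nM and 7500 nM.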

Compound 3, concentration for 50% growth inhibition: 37300 nM
The estimate for compound 3 lay 12-fold (1.07 log units) below the measured number, outside the stated range (above it).
By their numbers in this assay, from the lowest: compound 1; then compound 2; then compound 3.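

In this assay, the change from 4-methoxyphenyl to phenyl gives an 8.1-fold higher number from compound 2 to compound 3 (0.91 log units; beyond the scatter), so the methoxy at this place, para to a large group, goes with the lower number. The direction runs opposite to a 2.4-fold higher number from compound 1 to compound 2 (0.38 log units; beyond the scatter), where a methoxy entered at another place, so across these two steps the outcome of a methoxy depends on where it stands. Nothing measured here accounts for the size of the new step. Open, from the compounds shown here alone, is whether an ethoxy, a hydroxyl or an amine at this place would keep the number near that of compound 2, or whether only the methoxy does so.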